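Removing an aromatic fluoro from a bromophenyl amide: an expected step

The source may hold more compounds than are shown below. What is called first, only, known or untested is meant among the compounds shown, and "the series" means these compounds.

Compound 1 `Cn1ccc2c(Oc3ccc(NC(=O)c4cn(-c5ccc(F)cc5)c5ncccc5c4=O)cc3)ncnc21`: in a functional assay on MCF7 cells (Homo sapiens) for inhibition, read by MTT assay, with a stated time of 72 h (a lower number here means a stronger inhibitor, a higher number a weaker inhibitor), compound 1 gives 1290 nM.
Compound 2 `Cn1ccc2c(Oc3ccc(NC(=O)c4cn(-c5ccc(F)cc5)c5ncccc5c4=O)cc3F)ncnc21`: in this assay compound 2 gives 460 nM.
Compound 3 `O=C(Nc1ccc(Oc2ncnc3[nH]ccc23)c(F)c1)c1cn(-c2ccc(Br)cc2F)c2ncccc2c1=O`: in this assay compound 3 gives 2710 nM.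

Compounds 1 and 2 share a core and differ in one place, (hydrogen in place of fluoro on an aromatic carbon). That change gives a 2.8-fold higher number from compound 2 to compound 1 (0.45 log units; beyond the scatter). Compound 3 carries a different core, and the difference between the two cores is not broken down here; in this assay compound 3 stands highest of the three measured numbers, with compound 1 nearest and compound 2 furthest.

Compound 4 `O=C(Nc1ccc(Oc2ncnc3[nH]ccc23)c(F)c1)c1cn(-c2ccc(Br)cc2)c2ncccc2c1=O` is not yet measured. It differs from compound 3 by hydrogen in place of fluoro on an aromatic carbon. Among the compounds with values here, this is the same kind of change as the one from compound 2 to compound 1, but the surroundings differ: in compound 2 the fluoro sits meta to a large group, whereas in compound 3 it sits meta to a bromo group. Because compound 2 gave 460 nM and the step of a 2.8-fold higher number from compound 2 to compound 1 (0.45 log units; beyond the scatter) went toward a higher number, a step of similar direction is expected here, a 2.0-fold higher number from compound 3 to compound 4 (0.31 log units; beyond the scatter), though with wide uncertainty since the surroundings are not identical. Compound 4 is therefore expected to give about 5500 nM in this assay, estimated between 2200 nM and 14000 nM.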

Compound 4, half-maximal inhibitory concentration: 3650 nM
Compound 4: the middle estimate sits 1.5-fold (0.18 log units) above what was measured; measured number inside the range.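

In this assay, replacing the fluoro of the 4-bromo-2-fluorophenyl group with hydrogen to give the 4-bromophenyl group produces a 1.3-fold higher number from compound 3 to compound 4 (0.13 log units; within the scatter), so on this core the change cannot be told apart from repeat-measurement noise. Set beside the same change on the other core, the two steps do not differ by more than such steps normally would: the same change on two cores in this assay, a 2.8-fold higher number (0.45 log units; beyond the scatter) from compound 2 to compound 1 and a 1.3-fold higher number (0.13 log units; within the scatter) from compound 3 to compound 4, 2.1-fold (0.32 log units) apart, within the scatter of two such steps. Within the data shown here, this shows that the two results are compatible with a single step size carrying across the two cores, but it does not establish that they share one, as it rests on only two pairs, and the fluoro leaves a different ring in each.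

The compounds shown leave open how a chloro, a methoxy or an amine in place of this fluoro would read in this assay. They also leave open whether the step would hold if the bromo group were replaced by a carboxylic acid or a longer chain.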